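Notes on an aryl-amine series at the free fatty acid receptor

The compounds below may be only part of what the source reports. "The series", "measured", "known", "first", "only" and "open" are said of these compounds alone.

Measured so far:
compound 1 `O=C(O)/C=C/c1ccc(NCc2cccc(Oc3ccccc3)c2)cc1` — 76%
compound 2 `Cc1nc(-c2ccc(C(F)(F)F)cc2)sc1CNc1ccc(OCC(=O)O)cc1` — 100%
compound 3 `Cc1nc(-c2ccc(C(F)(F)F)cc2)sc1CNc1ccc(C(C)CC(=O)O)cc1` — 109%

All three numbers come from a functional assay on CHO cells for agonist activity at Free fatty acid receptor 1 (Homo sapiens), read by a luciferase reporter; a higher number here means a larger maximal response, a lower number a smaller maximal response. Compound 1 gives the lowest of the three maximal responses, 76% in this assay, while compound 2 reaches 100% and compound 3 reaches 109%; both of those lie beyond the scatter above compound 1.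

Among the measured compounds shown here, the only step between measured compounds, a number 9 percentage points higher from compound 2 to compound 3 (within the scatter), swaps one acid-bearing group for another on the shared core of compound 2 and changes little.

Compound 4 `CC(C)NC(=O)CCc1ccc(NCc2cccc(Oc3ccccc3)c2)cc1` is not yet measured. It differs from compound 1 in one place: 2-(isopropylcarbamoyl)ethyl in place of 2-carboxyethenyl on an aromatic carbon. For the measured compounds named here, no measured step covers this kind of change. The step from compound 2 to compound 3 keeps the acid on both sides and so does not bear on it. Every measured compound carries a carboxylic acid; compound 4 carries none, and its maximal response is therefore open. Compound 4 is expected to give about 45% in this assay, within 15% to 80%. That expectation means a step of a number 31 percentage points lower from compound 1 to compound 4 (beyond the scatter), a drop, with wide uncertainty.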

Compound 4, largest response reached (reported as percent of maximum), in percent of the reference or control that the assay uses: 66%
Beside the measured number, compound 4's estimate is 21 percentage points below it, and the stated range covers the measured number.
By their numbers in this assay, from the lowest: compounds 4 and 1 (each within the scatter of the next); then compounds 2 and 3 (each within the scatter of the next).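

In this assay, among the compounds shown here, the step of a number 10 percentage points lower from compound 1 to compound 4 (within the scatter) is the first reading on a compound without a carboxylic acid, and it shows that at this position, para to a large group, 2-(isopropylcarbamoyl)ethyl can stand in place of 2-carboxyethenyl with no change beyond the scatter. For this pair, then, a sizeable maximal response does not depend on the acid, although the swap also replaces a chain of 5 heavy atoms with one of 8 and removes one double bond. Nothing at hand bears on the reason for this result.

Still open, on these data alone, is which part of the swap the response tolerates, since a 2-carboxyethyl group on the core of compound 1 would separate the loss of the double bond from the loss of the acid. A primary amide or a longer chain at this position, and the same isopropyl amide on the core of compound 2, would show how far this single pair can be generalised.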